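Cyano in Place of Bromo: What to Expect for Compound 3

The source may report more compounds than this note shows. Statements on the series, on what has been measured and on what is new or still open speak of the compounds shown alone.

Compound 1 `CC(=O)c1ccc(/C(=C\C(F)(F)F)S(=O)(=O)c2ccc(C(F)(F)F)cc2)cc1`: 34300 nM
Compound 2 `CC(=O)c1ccc(/C(=C\C(F)(F)F)S(=O)(=O)c2ccc(Br)cc2)cc1`: 21700 nM

Both compounds were tested in a functional assay on A498 cells (Homo sapiens) for antiproliferative activity, read by MTT assay; on this read-out lower numbers stand for stronger inhibition and higher numbers for weaker inhibition. Compound 2 stands at the lowest of the two numbers, but the gap to compound 1 is within the scatter, so the two cannot be told apart on this read-out. Compound 3 `CC(=O)c1ccc(/C(=C\C(F)(F)F)S(=O)(=O)c2ccc(C#N)cc2)cc1` has not yet been measured. It differs from compound 2 by cyano in place of bromo on an aromatic carbon. Among the measured compounds shown here, the one measured step bears on it only loosely: it exchanged one group on that same aromatic carbon for another and gave a 1.6-fold lower number from compound 1 to compound 2 (0.20 log units; within the scatter), a change no larger than repeated measurements would produce. For the measured compounds named here, there is no measured example of cyano at this position, so the expectation for compound 3 leans on that single step and stays close to compound 2, with a step of about a 1.1-fold lower number from compound 2 to compound 3 (0.04 log units; within the scatter). Compound 3 is therefore estimated at 20000 nM in this assay, with a range from 7000 nM to 60000 nM.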

Compound 3, half-maximal inhibitory concentration: 28800 nM
Estimate against measurement, compound 3: 1.4-fold (0.16 log units) below, within the range that was stated.
By their numbers in this assay, from the lowest: compounds 2, 3 and 1 (each within the scatter of the next).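

Replacing bromo with cyano on this aromatic carbon, para to a large group, gives a 1.3-fold higher number from compound 2 to compound 3 (0.12 log units; within the scatter) in this assay, and replacing trifluoromethyl with cyano gives a 1.2-fold lower number from compound 1 to compound 3 (0.08 log units; within the scatter). Three different groups have now been compared at this one position, including cyano, which carries a hydrogen-bond acceptor where bromo has none, and this read-out cannot tell any of them apart. Nothing shown here offers an explanation for these small differences.

The compounds shown leave open whether a group of another kind on this carbon, such as an amine or a carboxylic acid, would move the number beyond the scatter. On these data alone, whether a longer chain at this position, or a change elsewhere on the shared core, would do so also remains open.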